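Cytotoxicity notes: from compound 2 to compound 4

The source may hold more compounds than are shown below. What is called first, only, known or untested is meant among the compounds shown, and "the series" means these compounds.

Three compounds of the series have been run in an ADME assay on HFF cells (Homo sapiens) for cytotoxicity, read by MTT assay, with a stated time of 72 h; on this read-out higher numbers stand for weaker inhibition and lower numbers for stronger inhibition. Compound 1 `Cc1ccc(-c2cn(C/C=C3\OC(=O)C(OCc4ccccc4)=C3OCc3ccccc3)nn2)cc1` reaches only the limit of the assay, > 100000 nM, which is a limit and not a number; see (the limit of > 100000 nM in this assay, at which 1 of the 3 values shown sits). Compound 2 `O=C1O[C@H]([C@@H](O)Cn2cc(-c3cccc(O)c3)nn2)C(OCc2ccccc2)=C1OCc1ccccc1` gives 39000 nM in this assay. Compound 3 `CC(C)(C)OC(=O)N1CCN(C(=S)SCc2cn(C[C@H](O)[C@H]3OC(=O)C(OCc4ccccc4)=C3OCc3ccccc3)nn2)CC1` gives 60 nM in this assay. Of the two numbers in hand, compound 2 stands highest; its nearest neighbour is compound 3, whose number lies far below it, well beyond the scatter.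

Compound 4 `Cc1ccc(-c2cn(C[C@H](O)[C@H]3OC(=O)C(OCc4ccccc4)=C3OCc3ccccc3)nn2)cc1` has not yet been measured. It differs from compound 2 in one place: 4-methylphenyl in place of 3-hydroxyphenyl on an aromatic carbon. For the measured compounds named here, no measured pair covers this change, so there is no measured guide to the size of the step. The step is expected to be small, a 1.3-fold higher number from compound 2 to compound 4 (0.11 log units; within the scatter), in either direction or none beyond the scatter. Compound 4 is estimated at 50000 nM in this assay, with a range from 15000 nM to 150000 nM, and a fair chance that only a limit is reported.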

Compound 4, half-maximal inhibitory concentration: > 100000 nM
Compound 4: no number, only a limit (the forecaster's own chance of this, stated with the estimate: 35%); at least 2.0-fold (0.30 log units) between middle value and limit.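

In this assay, the position on the aromatic carbon of the five-membered aromatic ring with 3 nitrogen now has its first measured step, with 4-methylphenyl in place of 3-hydroxyphenyl: an at least 2.5-fold higher number from compound 2 to compound 4 (0.40 log units; beyond the scatter). Compound 4 gives > 100000 nM, which is a limit of the assay and not a number. The 3-hydroxyphenyl is thus not required to keep the number high at this position, and the step is only a lower bound on the change, whose full size cannot be read: the limit of > 100000 nM in this assay, at which 2 of the 4 values shown sit.

The change swaps the hydroxyl for a methyl and moves the substituent on the phenyl ring at the same time, so the two effects stay unseparated. As far as these compounds go, how a plain phenyl or a 4-aminophenyl would read at this position also remains open.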